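The source may hold more compounds than are shown below. What is called first, only, known or untested is meant among the compounds shown, and "the series" means these compounds.

Measured compounds:
`NC1CCC(Nc2nc(NCc3ccc(Br)cc3)c3ncn(C4CCCC4)c3n2)CC1` compound 1, 1510 nM
`NC1CCC(Nc2nc(NCc3ccc(-c4ccsc4)cc3)c3ncn(C4CCCC4)c3n2)CC1` compound 2, 220 nM
`NC1CCC(Nc2nc(NCc3ccc(-c4ccccc4O)nc3)c3ncn(C4CCCC4)c3n2)CC1` compound 3, 16 nM

In a functional assay on HeLa cells (Homo sapiens) for inhibition, with a stated time of 72 h (a lower number here means a stronger inhibitor, a higher number a weaker inhibitor), compound 1 gives the highest number of the three measured compounds; compound 2 is nearest, compound 3 furthest, and both steps from compound 1 lie beyond the scatter. For the measured compounds named here, the only single-point step within this set is a 6.9-fold lower number from compound 1 to compound 2 (0.84 log units; beyond the scatter), which shows that exchanging the bromo on the benzyl ring for an aromatic substituent lowers the number markedly.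

Compound 4, `Nc1ccccc1CNc1nc(NC2CCC(N)CC2)nc2c1ncn2C1CCCC1`, has not been measured. It differs from compound 1 in this way: 2-aminophenyl in place of 4-bromophenyl on a saturated chain carbon bound to a nitrogen on an aromatic ring. Going by the values given here, no measured step covers this change; the bromine is removed rather than replaced by a further ring, and a donor and acceptor enter at a different position of the benzyl ring. The step from compound 1 to compound 2 bears on the same place only loosely, so little guidance follows from it. Compound 4 is therefore expected to stay near compound 1, with the change a 1.0-fold lower number from compound 1 to compound 4 (0.00 log units; within the scatter) inside or barely beyond the scatter, estimated at 1500 nM within a range of 450 nM to 5000 nM.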

Compound 4, half-maximal inhibitory concentration: 1030 nM
For compound 4 the middle estimate is 1.5-fold (0.16 log units) above the measured one; the measured number falls inside the stated range.
By their numbers in this assay, from the lowest: compound 3; then compound 2; then compounds 4 and 1 (each within the scatter of the next).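

In this assay, 2-aminophenyl in place of 4-bromophenyl on the saturated chain carbon gives a 1.5-fold lower number from compound 1 to compound 4 (0.17 log units; within the scatter), so at this place the exchange of bromine for an amino group on the phenyl ring, with its hydrogen-bond donor and acceptor, leaves the two compounds indistinguishable. The gap to the group carrying a further ring stays, with a 4.7-fold higher number from compound 2 to compound 4 (0.67 log units; beyond the scatter), so within this pair the lower number goes with 4-(thiophen-3-yl)phenyl and not with 2-aminophenyl. No measurement at hand explains either step.

Open, as far as these compounds go, is whether a hydroxyl or a carboxylic acid in place of the amino group of 2-aminophenyl would move the number. Also open, from the compounds shown here alone, is whether an aminomethyl group there, a longer chain ending in an amine, would behave as the amino group does.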